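Replacing a Nitrophenyl Amide with a Naphthyl Amide

A few compounds are considered here, and "the series" means these few. Any claim that something is new, unique, unknown or untested is made for them only; others in the source may bear on it.

Compound 1 `O=C(Nc1ccc([N+](=O)[O-])cc1OCc1ccccc1)c1ccc(Cl)c([N+](=O)[O-])c1` and compound 2 `O=C(Nc1ccc([N+](=O)[O-])cc1OCc1ccccc1)c1ccc2ccccc2c1` differ only on the carbonyl carbon, through (naphthalen-2-yl in place of 4-chloro-3-nitrophenyl on a carbonyl carbon). In an assay on SK-BR-3 cells for inhibition of Aromatase (Homo sapiens) (on this read-out higher numbers stand for weaker inhibition and lower numbers for stronger inhibition), compound 1 gives > 25000 nM, a limit of the assay rather than a number. Compound 2 in this assay also gives only a limit, > 25000 nM. The step that the two limits leave unreadable from compound 1 to compound 2 therefore cannot be sized, because of the limit of > 25000 nM in this assay, at which 2 of the 3 values shown sit.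

Compound 3 `CN(c1ccc(NC(=O)c2ccc(Cl)c([N+](=O)[O-])c2)cc1OCc1ccccc1)S(C)(=O)=O` has a different core; how its core differs from that of compound 1 is not broken down here. In this assay, going by the values given here, compound 3 gives 690 nM, the only number among the three. Compound 4 `CN(c1ccc(NC(=O)c2ccc3ccccc3c2)cc1OCc1ccccc1)S(C)(=O)=O` carries the same change, (naphthalen-2-yl in place of 4-chloro-3-nitrophenyl on a carbonyl carbon). Since the earlier step is unreadable, the expectation rests only on compound 3 at 690 nM, and the expected step of a 2.9-fold higher number from compound 3 to compound 4 (0.46 log units; beyond the scatter) is a modest loss. The estimate for compound 4 in this assay is 2000 nM, between 400 nM and 15000 nM.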

Compound 4, half-maximal inhibitory concentration: 1070 nM
For compound 4 the middle estimate is 1.9-fold (0.27 log units) above the measured one; low and high end bracket the measured number.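

In this assay, replacing 4-chloro-3-nitrophenyl with naphthalen-2-yl on the core of compound 3 gives a 1.6-fold higher number from compound 3 to compound 4 (0.19 log units; within the scatter), so on this core the two groups cannot be told apart. Going by these compounds alone, this single pair is the only readable instance of the change, and it shows no rule for the series. The matching step on the core of compound 1 cannot be read, so whether the change carries from one core to the other remains unshown: the limit of > 25000 nM in this assay, at which 2 of the 4 values shown sit.

The compounds shown leave open how a group carrying an amine or a carboxylic acid would read on the carbonyl carbon. They also leave open whether a third core would give a readable step for the same change.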